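Swapping a fluorinated ring for a phenoxy group

This account rests on a few compounds, and the source may have more. Where it says the series, first, only, none or still open, it means among the compounds named here.

Measured so far:
compound 1, `N#CN1CC(OCc2ccc(-c3ccccc3)cc2)C1`: 2.8 nM
compound 2, `N#CN1CC(OCc2ccc(-c3ccc(C(F)(F)F)cc3)cc2)C1`: 1.6 nM
compound 3, `N#CN1CC(OCc2ccc(-c3ccc(F)cc3)cc2)C1`: 0.68 nM

In an assay on isolated protein for inhibition of N-acylethanolamine-hydrolyzing acid amidase (Homo sapiens), read by fluorescence, with a stated time of 90 min (on this read-out higher numbers stand for weaker inhibition and lower numbers for stronger inhibition), compound 3 gives the lowest number of the three. The steps that lead to it are a 4.1-fold lower number from compound 1 to compound 3 (0.61 log units; beyond the scatter) and a 2.4-fold lower number from compound 2 to compound 3 (0.37 log units; beyond the scatter), while the step of a 1.8-fold lower number from compound 1 to compound 2 (0.24 log units; within the scatter) is smaller. All three steps change only the substituent on the outer ring; none of them touches the link between the two rings.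

Compound 4, `N#CN1CC(OCc2ccc(Oc3ccccc3)cc2)C1`, does exactly that: phenoxy in place of 4-fluorophenyl on an aromatic carbon. The outer ring is kept, but it now hangs from an oxygen instead of sitting directly on the core, and the fluorine is gone. Among the compounds with values here, no measured step covers this kind of change, so the expectation must lean on the general picture: the unsubstituted compound 1 and the substituted compounds 2 and 3 all give low numbers in this assay, suggesting the outer ring is tolerated in several forms. Losing the fluorine alone would be expected to cost something, judging from compound 1 against compound 3, and the new linkage adds further uncertainty. Compound 4 is therefore expected to give 4 nM in this assay, a step of a 5.9-fold higher number from compound 3 to compound 4 (0.77 log units; beyond the scatter), with a plausible range from 0.8 nM to 20 nM.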

Compound 4, half-maximal inhibitory concentration: 1.1 nM
Compound 4: middle estimate off by 3.6-fold (0.56 log units), on the high side; the range from low to high includes it.
By their numbers in this assay, from the lowest: compounds 3, 4, 2 and 1 (each within the scatter of the next, the first and the last beyond it).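

Phenoxy can stand in place of 4-fluorophenyl on this aromatic carbon with no change that can be told from the scatter in this assay, the step being a 1.6-fold higher number from compound 3 to compound 4 (0.21 log units; within the scatter). Set against plain phenyl, phenoxy gives a 2.5-fold lower number from compound 1 to compound 4 (0.41 log units; beyond the scatter), so in this small set the outer ring does not need to sit directly on the core, nor to carry a fluorine, for compound 4 to give a number level with that of compound 3. Still open, from the compounds shown here alone, is whether these low numbers would hold with a fluoro or trifluoromethyl group on the phenoxy ring, with an amine or a carboxylic acid there, or with a longer link such as benzyloxy. No independent measurement is available to explain how the phenoxy group achieves this result.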